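The source may report more compounds than this note shows. Statements on the series, on what has been measured and on what is new or still open speak of the compounds shown alone.

Series in a functional assay on cells for agonist activity at Free fatty acid receptor 1 (Mus musculus), read by FLIPR and calcium flux, with a stated time of 100 s; a higher number here means that more compound is needed for the effect, a lower number that less compound is needed:
compound 1 `Cc1ccccc1Oc1ccc(N2C[C@@H](C(F)(F)F)C[C@H]2CC(=O)O)cc1` — 330 nM
compound 2 `Cc1ccccc1Oc1ccc(N2CCC[C@H]2CC(=O)O)cc1` — 5600 nM
compound 3 `CC(C)(C)c1ccccc1Oc1ccc(N2CCC[C@H]2CC(=O)O)cc1` — see below

Going by the values given here, compound 2 stands highest of the two numbers in this assay; the only other number belongs to compound 1, with a 17-fold higher number from compound 1 to compound 2 (1.23 log units; beyond the scatter). For compound 3 this assay gives only a limit, > 17000 nM. Within the aryl ether, an at least 3.0-fold higher number from compound 2 to compound 3 (0.48 log units; beyond the scatter) shows that an exchange on this ring can move the number beyond the scatter.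

Compound 4 `O=C(O)C[C@@H]1CCCN1c1ccc(Oc2cccc(Cl)c2)cc1` differs from compound 2 by 3-chlorophenyl in place of 2-methylphenyl on an oxygen on an aromatic ring. Neither measured step covers this exchange; the step on the same ring ran toward a higher number and was at least modest, so for compound 4 a step of at most modest size is expected, direction uncertain, a 1.1-fold lower number from compound 2 to compound 4 (0.05 log units; within the scatter). Compound 4 is estimated at 5000 nM, in the range 1500 nM to 15000 nM.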

Compound 4, half-maximal effective concentration: > 16000 nM
Compound 4: a limit, no number; the forecaster's own chance of this, stated with the estimate: 10%; middle value at least 3.2-fold (0.50 log units) from the limit.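

In this assay, compound 4 gives a limit and not a number: the limit of > 16000 nM in this assay, at which 1 of the 4 values shown sits. The exchange of 2-methylphenyl for 3-chlorophenyl on an oxygen on an aromatic ring still gives an at least 2.8-fold higher number from compound 2 to compound 4 (0.45 log units; beyond the scatter) and so moves the number beyond the scatter. Both exchanges on this ring now run toward a higher number, and neither exception nor gain appears among the compounds shown.

As far as these compounds go, the true size of this step stays open. Also open, from the compounds shown here alone, is how a nitrile or a methoxy group on this ring would read, and whether trifluoromethyl on the saturated ring, as in compound 1, would change the reading of the 3-chlorophenyl ether.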